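Swapping nitro for chloro on a dopamine receptor agonist

The source may report more compounds than this note shows. Statements on the series, on what has been measured and on what is new or still open speak of the compounds shown alone.

Measured so far in a functional assay on HEK293 cells for agonist activity at D(4) dopamine receptor (Homo sapiens), read by FLIPR; on this read-out lower numbers stand for smaller maximal responses and higher numbers for larger maximal responses:
compound 1 `Cc1ccc([N+](=O)[O-])cc1NC(=O)CN1CCC(c2cccc[n+]2[O-])CC1` gives 76%;
compound 2 `O=C(NCN1CCC(c2cccc[n+]2[O-])CC1)c1cnccc1Cl` gives 44%;
compound 3 `Cc1cccc(NC(=O)CN2CCC(c3ccc(O)cn3)CC2)c1` gives 83%.

Among these three, compound 1 stands second highest. Compound 3 is nearest, at a value within the usual scatter, so the two cannot be told apart on this read-out. Compound 2 lies furthest away, beyond the scatter. Compound 4 `Cc1ccc(Cl)cc1NC(=O)CN1CCC(c2cccc[n+]2[O-])CC1` differs from compound 1 in one place: chloro in place of nitro on an aromatic carbon. Within the data shown here, no measured pair shows this same change, so the size of its effect is unknown from the data. With nothing pointing either way, the expected step, a number 6 percentage points lower from compound 1 to compound 4 (within the scatter), is small, no bigger than the scatter. Compound 4 is estimated to reach 70% in this assay, with a range from 50% to 90%.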

Compound 4, largest response reached (reported as efficacy), in percent of the reference or control that the assay uses: 58%
Compound 4: middle estimate off by 12 percentage points, on the high side, within the range that was stated.
By their numbers in this assay, from the lowest: compound 2; then compound 4; then compounds 1 and 3 (each within the scatter of the next).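

The position para to the methyl group is sensitive to what sits there: in this assay, chloro in place of nitro gives a number 18 percentage points lower from compound 1 to compound 4 (beyond the scatter). Among these compounds, this is the first measured pair for this change, so the change now has a size, though only on this one core. Nothing measured here explains the step.

The compounds shown leave open how a nitrile, a methoxy group or an amine would fare at this position. They also leave open whether the same swap would give a similar step on another core.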